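Aryl swap from compound 2 to compound 4

The compounds below may be only part of what the source reports. "The series", "measured", "known", "first", "only" and "open" are said of these compounds alone.

Measured so far:
compound 1 `CC(C)(C)CC[C@H](c1ccc(C(=O)NCc2nn[nH]n2)cc1)N1C(=O)C(c2cncc(Cl)c2)=N[C@]12CC[C@@H](C(C)(C)C)CC2`: 84 nM
compound 2 `CC(C)(C)[C@H]1CC[C@]2(CC1)N=C(c1ccc(Cl)cc1)C(=O)N2Cc1ccc(C(=O)NCCC(=O)O)cc1`: > 10000 nM
compound 3 `CC(C)(C)CC[C@H](c1ccc(C(=O)NCc2nn[nH]n2)cc1)N1C(=O)C(c2ccc(C(F)(F)F)cc2)=N[C@]12CC[C@@H](C(C)(C)C)CC2`: 190 nM

In an assay on membranes from liver for displacement of a labelled ligand from Glucagon receptor (Mus musculus), read by scintillation counting, with a stated time of 60 min (a lower number here means a stronger inhibitor, a higher number a weaker inhibitor), compound 1 gives 84 nM and compound 3 gives 190 nM. Among the measured compounds shown here, for compound 2 the result is a limit of the assay, > 10000 nM; it is the one value of the three that sits at the limit of > 10000 nM in this assay, at which 1 of the 3 values shown sits. Compound 4 `CC(C)(C)[C@H]1CC[C@]2(CC1)N=C(c1cccc(C(F)(F)F)c1)C(=O)N2Cc1ccc(C(=O)NCCC(=O)O)cc1` is not yet measured. It differs from compound 2 by 3-(trifluoromethyl)phenyl in place of 4-chlorophenyl on a carbon with a double bond to nitrogen. For the measured compounds named here, the only measured step at the same place is a 2.3-fold higher number from compound 1 to compound 3 (0.35 log units; beyond the scatter), seen in compounds 1 and 3, whose remaining structure differs from that of compound 2. That step is modest, and compound 2 starts at a limit, so the expected step of a number no higher from compound 2 to compound 4 (the limit leaves the size open) leaves compound 4 at or near the limit as well. Compound 4 is therefore estimated at 10000 nM, with a range from 4000 nM to 30000 nM.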

Compound 4, half-maximal inhibitory concentration: 10000 nM
The estimate for compound 4 equals the measured number at the digits printed; measured number inside the range.
By their numbers in this assay, from the lowest: compound 1; then compound 3; then compound 4.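

In this assay compound 2 is a limit of the assay, > 10000 nM. Compound 4 gives 10000 nM. On this core, 3-(trifluoromethyl)phenyl in place of 4-chlorophenyl gives a number no higher from compound 2 to compound 4 (the limit leaves the size open), though the size of the step cannot be read: the limit of > 10000 nM in this assay, at which 1 of the 4 values shown sits. Among the compounds shown here, the earlier step between compound 1 and compound 3 came from a different remaining structure, whereas this pair gives the first reading of the position on the core of compound 2.

Still open, going by these compounds, is whether any aryl group here moves this core clear of the limit. On these data alone, how an amine or a nitrile on this aryl ring would read also remains open.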